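A few compounds are considered here, and "the series" means these few. Any claim that something is new, unique, unknown or untested is made for them only; others in the source may bear on it.

Compound 1 `COc1ccc(/C=C\C(=O)O[C@@H](C)[C@@H]2CC[C@H]([C@H](O)[C@H]3CC=CC(=O)O3)O2)cc1` carries a methoxy group on its aromatic ring and a double bond drawn Z. In a functional assay on HEp-2 cells (Homo sapiens) for inhibition, read by sulforhodamine B assay, with a stated time of 72 h (a lower number here means a stronger inhibitor, a higher number a weaker inhibitor), compound 1 reaches only the limit of the assay, > 10000 nM, which is a limit and not a number. Compound 2 `C[C@H](OC(=O)/C=C\c1ccc(O)cc1)[C@@H]1CC[C@H]([C@H](O)[C@H]2CC=CC(=O)O2)O1` keeps the Z double bond but has hydrogen in place of methyl on the aromatic oxygen (hydrogen in place of methyl on an oxygen on an aromatic ring); in this assay compound 2 gives 7700 nM. Compound 3 `COc1ccc(/C=C/C(=O)O[C@@H](C)[C@@H]2CC[C@H]([C@H](O)[C@H]3CC=CC(=O)O3)O2)cc1` differs from compound 1 only in configuration as drawn (the two compounds have the same atoms and bonds and differ only in configuration as drawn: 1 of 6 stereo elements differ; a double bond is drawn Z in compound 1 and E in compound 3), and in this assay compound 3 gives 5700 nM. The step of an at least 1.2-fold lower number from compound 1 to compound 2 (0.11 log units; that floor lies within the scatter) and the step of an at least 1.7-fold lower number from compound 1 to compound 3 (0.24 log units; that floor lies within the scatter) can be given only as floors because of the limit of > 10000 nM in this assay, at which 1 of the 3 values shown sits, and the latter rests on nothing but (the fact that compounds 1 and 3 differ only in the configuration as drawn).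

Compound 4 `C[C@H](OC(=O)/C=C/c1ccc(O)cc1)[C@@H]1CC[C@H]([C@H](O)[C@H]2CC=CC(=O)O2)O1` has not yet been measured in this assay. It stands to compound 3 as compound 2 stands to compound 1, the same change hydrogen in place of methyl on an oxygen on an aromatic ring at the same place. Since the step from compound 1 to compound 2 sat within the scatter, the expected step of a 1.3-fold lower number from compound 3 to compound 4 (0.10 log units; within the scatter) is estimated to be small. Compound 4 is therefore expected to give about 4500 nM in this assay, plausibly between 1500 nM and 12000 nM.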

Compound 4, half-maximal inhibitory concentration: > 10000 nM
Compound 4 was reported as a limit; the forecaster's own chance of this, stated with the estimate: 15%; middle value at least 2.2-fold (0.34 log units) from the limit.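

In this assay compound 4 gives > 10000 nM, which is a limit of the assay and not a number. The step of an at least 1.7-fold higher number from compound 3 to compound 4 (0.24 log units; that floor lies within the scatter) and the step of an at least 1.2-fold higher number from compound 2 to compound 4 (0.11 log units; that floor lies within the scatter) can therefore be read only as floors, because of one thing: the limit of > 10000 nM in this assay, at which 2 of the 4 values shown sit. The change from methoxy to hydroxy is thus neither shown to carry over from the core of compound 1 to the core of compound 3 nor shown to behave differently there: the same change on two cores in this assay, an at least 1.2-fold lower number (0.11 log units; that floor lies within the scatter) from compound 1 to compound 2 and an at least 1.7-fold higher number (0.24 log units; that floor lies within the scatter) from compound 3 to compound 4; the limit leaves it open whether they differ.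

The compounds shown leave open what number compound 4 would give beyond the limit, and so how large the difference is between the forms drawn Z and E when the aromatic ring carries hydroxy. They also leave open what this assay would report with a different group on the oxygen on the aromatic ring, such as a longer chain in place of methyl, or with an amine or a carboxylic acid in place of methoxy.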